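The source may hold more compounds than are shown below. What is called first, only, known or untested is meant among the compounds shown, and "the series" means these compounds.

Measured compounds in a functional assay on SK-MEL-28 cells (Homo sapiens) for cytotoxicity, read by sulforhodamine B assay, with a stated time of 48 h, tested at 10 uM; a lower number here means a stronger effect, a higher number a weaker effect of the compound at the concentration tested:
- compound 1 `COc1cc(-c2cc(/C=C/C(=O)c3ccc(Cl)c(Cl)c3)[nH]n2)cc(OC)c1OC` gives 73%
- compound 2 `COc1ccc(C(=O)/C=C/c2cc(-c3cc(OC)c(OC)c(OC)c3)n[nH]2)cc1OC` gives -88%
- compound 3 `COc1ccc(C(=O)/C=C/c2cc(-c3cc(OC)c(OC)c(OC)c3)n[nH]2)cc1` gives -55%

Among these three numbers compound 3 stands second highest: its nearest neighbour is compound 2, with a number 33 percentage points higher from compound 2 to compound 3 (beyond the scatter) separating them, and the furthest is compound 1, with a number 128 percentage points lower from compound 1 to compound 3 (beyond the scatter). Both steps away from compound 1 were large and in the same direction: a number 161 percentage points lower from compound 1 to compound 2 (beyond the scatter) and a number 128 percentage points lower from compound 1 to compound 3 (beyond the scatter), both replacing the halogen-bearing ring on the carbonyl carbon with a methoxy-bearing one.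

Compound 4 `COc1cc(-c2cc(/C=C/C(=O)c3ccc(F)c(F)c3)[nH]n2)cc(OC)c1OC` has not yet been measured in this assay. It differs from compound 3 in one place: 3,4-difluorophenyl in place of 4-methoxyphenyl on a carbonyl carbon. The change runs opposite to the two measured steps from compound 1, since a ring bearing methoxy leaves and a ring bearing two halogens enters on the carbonyl carbon. Because of a number 128 percentage points lower from compound 1 to compound 3 (beyond the scatter) a step upward, back toward the number of compound 1, is therefore expected, though the two halogens in compound 4 are fluorines rather than the chlorines of compound 1, so the full return is not assumed. The step is estimated as a number 90 percentage points higher from compound 3 to compound 4 (beyond the scatter). For compound 4 the estimate is 35%, with a range from -10% to 80%.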

Compound 4, a percentage reported as activity, at one concentration (the size of the read-out at that concentration, not a potency): 32%
For compound 4 the middle estimate is 3 percentage points above the measured one; the range from low to high includes it.
By their numbers in this assay, from the lowest: compound 2; then compound 3; then compound 4; then compound 1.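

In this assay, the result shows that the link between a halogen-bearing ring on the carbonyl carbon and a weaker effect at the concentration tested is not confined to 3,4-dichlorophenyl. Exchanging either methoxy-bearing ring for 3,4-difluorophenyl moves the number strongly upward (a number 87 percentage points higher from compound 3 to compound 4 (beyond the scatter); a number 120 percentage points higher from compound 2 to compound 4 (beyond the scatter)). The earlier compounds shown here also could not show whether the identity of the halogen matters, and here the two halogen-bearing rings are not interchangeable (a number 41 percentage points lower from compound 1 to compound 4 (beyond the scatter)), so compound 4 falls between the two methoxy-bearing compounds and compound 1. No measurement available here accounts for these differences.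

The compounds shown leave open how the number would move with an amine, a carboxylic acid or a bromine on the ring at the carbonyl carbon. As far as these compounds go, the rest of the core is the same in all four compounds, so it also remains open whether the same order of rings would hold if that part carried a different group.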